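The compounds below may be only part of what the source reports. "The series", "measured", "known", "first", "only" and "open" are said of these compounds alone.

Working notes on the series. Compound 1 `O=C(Nc1cccc(-n2cc(-c3ccncc3)c(-c3ccc(Cl)c(O)c3)n2)c1)Nc1ccc(Cl)c(Cl)c1` was run in a functional assay on SNB-19 cells (Homo sapiens) for inhibition, read by sulforhodamine B assay, with a stated time of 48 h; a lower number here means that less compound is tolerated, a higher number that more compound is tolerated. In this assay compound 1 gives only a limit, > 32500 nM, so no number stands for it. Compound 2 `COc1cc(-c2nn(-c3cccc(NC(=O)c4ccccc4)c3)cc2-c2ccncc2)ccc1Cl` was run in this assay as well. Compound 2 also returns only a limit, > 100000 nM. Among the measured compounds shown here, both measured values are therefore limits of the assay, and no step between measured compounds can be read from them. Compound 3 `O=C(Nc1cccc(-n2cc(-c3ccncc3)c(-c3ccc(Cl)c(O)c3)n2)c1)Nc1ccc(Cl)c(C(F)(F)F)c1` has not yet been measured. It differs from compound 1 by trifluoromethyl in place of chloro on an aromatic carbon. With compound 1 sitting at a limit, no step beyond the usual scatter is expected in this assay, and the expected step from compound 1 to compound 3 is a step that the limit leaves unreadable from compound 1 to compound 3. Compound 3 is thus estimated at 45000 nM, with a range from 20000 nM to 150000 nM, and most likely this assay will again report only a limit for compound 3 rather than a number.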

Compound 3, concentration lethal to 50% of the cells: > 32500 nM
Compound 3: only a limit was reported (the forecaster's own chance of this, stated with the estimate: 75%); the middle value is on the limit's open side.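

Compound 1 and compound 3 each return only a limit in this assay, and no step can be read between them for trifluoromethyl in place of chloro. Whether any compound shown gives a measurable number in this assay remains open.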